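This account rests on a few compounds, and the source may have more. Where it says the series, first, only, none or still open, it means among the compounds named here.

Measured in a functional assay on HCT-116 cells (Homo sapiens) for cytotoxicity, read by MTT assay, with a stated time of 72 h; a higher number here means a weaker inhibitor, a lower number a stronger inhibitor:
- compound 1 `N[C@H]1CC[C@H](Nc2c(C(=O)NCc3ccc(Oc4ccccc4)cc3)nc(Br)c3cccnc23)CC1`: "not determined" (no result reported)
- compound 2 `O=C(NCc1ccc(F)cc1)c1nc(Br)c2cccnc2c1NCc1ccc(F)cc1`: > 20000 nM, a limit
- compound 3 `CN(C)CCCNc1c(C(=O)NCc2ccc(F)cc2)nc(Br)c2cccnc12`: > 10000 nM, a limit

Compound 1 stands at "not determined" (no result reported) in this assay, so the step under study has no measured starting point. Going by the values given here, the only readings nearby are limits, and neither gives a number. Compound 2 is a limit at > 20000 nM. Compound 3 is a limit at > 10000 nM.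

Compound 4 `COc1ccc(CNC(=O)c2nc(Br)c3cccnc3c2N[C@H]2CC[C@H](N)CC2)cc1` differs from compound 1 by one change: methyl in place of phenyl on an oxygen on an aromatic ring. In words, this is methyl in place of phenyl on an oxygen on an aromatic ring, or phenoxy to methoxy.

Among the compounds with values here, the only measured step is a step that the two limits leave unreadable from compound 2 to compound 3. It has no readable size and concerns a different place in the structure, so it does not bear directly on this change. No size or direction can therefore be expected for the change in this assay. The estimate for compound 4 rests only on the two limits and is correspondingly wide, and a result reported only as a limit would not be surprising.

Compound 4 is expected at 6000 nM, with an estimated range of 1000 nM to 30000 nM.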

Compound 4, half-maximal inhibitory concentration: 3000 nM
Compound 4: the middle estimate sits 2.0-fold (0.30 log units) above what was measured; the range from low to high includes it.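

Compound 4 gives 3000 nM in this assay, but compound 1 has no number to set against it, so no step can be read between compound 1 and compound 4. The compounds shown leave open how phenoxy and methoxy compare on the shared core in this assay. Nothing shown accounts for the value of compound 4.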